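The compounds below may be only part of what the source reports. "The series", "measured", "known", "first", "only" and "open" are said of these compounds alone.

Compound 1 `O=C(O)c1cc(-n2cccc2)ccc1O`: 50 mg/kg; compound 2 `O=C(O)c1cc(-n2nccn2)ccc1O`: 150 mg/kg; compound 3 `O=C(O)c1cc(-c2ccno2)ccc1O`: 110 mg/kg.

In a functional assay on the whole organism for inhibition, with Rattus norvegicus as the target, read by paw edema (a higher number here means that more compound is needed for the effect, a lower number that less compound is needed), compound 1 holds the lowest number of the three measured compounds. The steps away from it are a 3.0-fold higher number from compound 1 to compound 2 (0.48 log units; beyond the scatter) and a 2.2-fold higher number from compound 1 to compound 3 (0.34 log units; beyond the scatter), while between the other two a 1.4-fold lower number from compound 2 to compound 3 (0.13 log units; within the scatter). Compound 4 `O=C(O)c1cc(-n2cncn2)ccc1O` differs from compound 1 by 1H-1,2,4-triazol-1-yl in place of 1H-pyrrol-1-yl on an aromatic carbon. Both measured steps from compound 1 replace 1H-pyrrol-1-yl with another five-membered aromatic ring and both raise the number modestly, so a comparable modest rise is expected here as well, namely a 2.6-fold higher number from compound 1 to compound 4 (0.41 log units; beyond the scatter). For compound 4 the estimated value is 130 mg/kg, with a range from 60 mg/kg to 280 mg/kg.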

Compound 4, dose for half-maximal effect: 200 mg/kg
Compound 4: the middle estimate sits 1.5-fold (0.19 log units) below what was measured; the measured number falls inside the stated range.
By their numbers in this assay, from the lowest: compound 1; then compounds 3, 2 and 4 (each within the scatter of the next).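

With a third replacement of 1H-pyrrol-1-yl on this aromatic carbon, meta to the carboxy group and para to the hydroxy group, the number again rises, with a 4.0-fold higher number from compound 1 to compound 4 (0.60 log units; beyond the scatter). The replacements do not separate from one another, with a 1.3-fold higher number from compound 2 to compound 4 (0.12 log units; within the scatter) and a 1.8-fold higher number from compound 3 to compound 4 (0.26 log units; within the scatter), so moving from one triazole arrangement to the other shows no distinct effect. Nothing available explains why compound 1 holds the lowest number.

The compounds shown leave open how a phenyl ring, a morpholine or a simple amine at this position would compare with 1H-pyrrol-1-yl.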